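Swapping a methylfuran for a methylphenyl on a cyanoacrylamide

This account rests on a few compounds, and the source may have more. Where it says the series, first, only, none or still open, it means among the compounds named here.

Of the compounds shown here, three have been measured in a functional assay on NCI-H460 cells (Homo sapiens) for inhibition, read by MTT assay, with a stated time of 72 h; a lower number here means a stronger inhibitor of growth, a higher number a weaker inhibitor of growth. Compound 1 `N#C/C(=C\c1c(F)c(F)c(F)c(F)c1F)C(=O)c1c[nH]c2ccccc12` gives 35000 nM. Compound 2 `N#C/C(=C\c1ccco1)C(=O)NCc1ccc(Cl)c(Cl)c1` reaches only a limit of the assay, > 50000 nM, the one described by the limit of > 50000 nM in this assay, at which 1 of the 3 values shown sits. Compound 3 `COc1ccc(CNC(=O)/C(C#N)=C/c2ccc(C)o2)cc1` likewise returns only a limit, > 100000 nM, the one described by the limit of > 100000 nM in this assay, at which 1 of the 3 values shown sits. So compound 3 stands at the upper limit of this assay, with no number of its own, and no step between two measured compounds with a single change is available here.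

Compound 4 `COc1ccc(CNC(=O)/C(C#N)=C/c2ccc(C)cc2)cc1` differs from compound 3 in one place: 4-methylphenyl in place of 5-methylfuran-2-yl on a double-bonded chain carbon bound to a double-bonded chain carbon. The step from compound 3 to compound 4 cannot be read off from any measured pair, and the values of compound 1 and compound 2 do not bear on this particular exchange. Given that compound 3 sits at a limit and both other compounds are weak or beyond a limit, no step beyond the scatter is expected in either direction; the step from compound 3 to compound 4 is expected to be a number no higher from compound 3 to compound 4 (the limit leaves the size open). Compound 4 is therefore estimated at 100000 nM, within a range from 30000 nM to 300000 nM, with a good chance that this assay again reports only a limit.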

Compound 4, concentration for 50% growth inhibition: 41000 nM
Estimate against measurement, compound 4: 2.4-fold (0.39 log units) above, and the stated range covers the measured number.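

In this assay, going by these compounds alone, the ring at this place, on a double-bonded chain carbon bound to a double-bonded chain carbon, proves able to move the read-out: 4-methylphenyl in place of 5-methylfuran-2-yl gives an at least 2.4-fold lower number from compound 3 to compound 4 (0.38 log units; beyond the scatter) and is the first single exchange in this set that can be read at all. With this change, compound 4 gives 41000 nM as a number of its own, so the amide part it shares with compound 3 can go with a measured value, although the growth inhibition remains in a weak range. The step has a lower bound only, and its full size stays unknown, because compound 3 stands at a limit of the assay: the limit of > 100000 nM in this assay, at which 1 of the 4 values shown sits.

The compounds shown leave open whether the methyl on the six-membered ring contributes, and whether a plain phenyl, a 4-aminophenyl or a 4-carboxyphenyl at this place would shift the number further. From the compounds shown here alone, it also remains open whether the same exchange of rings would give a comparable step on the amide part of compound 2.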